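Cytotoxicity notes on a quinolinone benzylamine series

The source may report more compounds than this note shows. Statements on the series, on what has been measured and on what is new or still open speak of the compounds shown alone.

Measured compounds:
- Compound 1 `Cc1ccc2cc(CN(Cc3ccc(F)cc3)Cc3ccc(C(C)C)cc3)c(=O)[nH]c2c1` — in a toxicity assay on MDCK cells (Canis lupus familiaris) for cytotoxicity, read by crystal violet staining, with a stated time of 48 h (on this read-out lower numbers stand for higher toxicity in this test and higher numbers for lower toxicity in this test), compound 1 gives > 33000 nM, a limit of the assay.
- Compound 2 `CCc1ccc(CN(Cc2ccc(F)cc2)Cc2cc3ccc(C)cc3[nH]c2=O)cc1` — in this assay compound 2 gives > 33000 nM, a limit of the assay.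
- Compound 3 `Cc1ccc2[nH]c(=O)c(CN(Cc3cccc(F)c3)Cc3ccc4ccccc4c3)cc2c1` — in this assay compound 3 gives > 5000 nM, a limit of the assay.

Compound 2 and compound 1 differ by methyl in place of hydrogen on a saturated chain carbon bound to an aromatic carbon and a saturated chain carbon. Both values are limits, so the step that the two limits leave unreadable from compound 2 to compound 1 cannot be read; what can be said is that both sit at the limit of > 33000 nM in this assay, at which 2 of the 3 values shown sit. Compound 3 sits at the limit of > 5000 nM in this assay, at which 1 of the 3 values shown sits, and the difference between its core and that of compound 2 is not broken down here.

Compound 4 `CCc1ccc2[nH]c(=O)c(CN(Cc3cccc(F)c3)Cc3ccc4ccccc4c3)cc2c1` is not yet measured. It differs from compound 3 by methyl in place of hydrogen on a saturated chain carbon bound to an aromatic carbon. For the measured compounds named here, this is the same kind of change as the one from compound 2 to compound 1, but the place is not identical: in the earlier pair the carbon is bound to an aromatic carbon and a saturated chain carbon, whereas here it is bound to an aromatic carbon only. The earlier pair gives no readable step, so no direction is taken from it; the expectation rests on all three measured compounds reporting limits. Compound 4 is therefore expected to show a step that the limit leaves unreadable from compound 3 to compound 4 in this assay, and is expected to come out near 40000 nM, within roughly 10000 nM to 120000 nM, most likely again as a limit rather than a number.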

Compound 4, half-maximal cytotoxic concentration: > 5000 nM
Compound 4: only a limit was reported (the forecaster's own chance of this, stated with the estimate: 85%); the middle value does not contradict the limit.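

Compound 3 and compound 4 both report only a limit in this assay, so no step can be read between them, and the methyl in place of hydrogen gains no readable size here. The compounds shown leave open where the half-maximal cytotoxic concentration of any of the four compounds actually lies, and whether this change shifts it at all.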